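The compounds below may be only part of what the source reports. "The series", "measured", "known", "first", "only" and "open" are said of these compounds alone.

Measured compounds:
compound 1, `COc1ccc2c(/C=C/C(=O)c3cc(OC)c(OC)c(SC)c3)c[nH]c2c1`, 131 nM
compound 2, `COc1ccc2c(/C=C/C(=O)c3cc(N)c(OC)c(OC)c3)c[nH]c2c1`, 155 nM
compound 3, `COc1cc(C(=O)/C=C/c2cn(C)c3ccccc23)cc(SC)c1OC`, 105 nM

These three were tested in a functional assay on HeLa cells (Homo sapiens) for antiproliferative activity, read by MTT assay, with a stated time of 48 h; on this read-out higher numbers stand for weaker inhibition and lower numbers for stronger inhibition. Compound 1 and compound 2 differ by one change, (amino in place of methylsulfanyl on an aromatic carbon), and the step it made is a 1.2-fold higher number from compound 1 to compound 2 (0.07 log units; within the scatter). Compound 3 carries the methylsulfanyl group of compound 1 on a core whose difference from the core of compound 1 is not broken down here; in this assay its value and those of compound 1 and compound 2 all lie within the scatter of one another.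

Compound 4, `COc1cc(C(=O)/C=C/c2cn(C)c3ccccc23)cc(N)c1OC`, stands to compound 3 as compound 2 stands to compound 1: the change is amino in place of methylsulfanyl on an aromatic carbon, the same change at the same place. Because a 1.2-fold higher number from compound 1 to compound 2 (0.07 log units; within the scatter) was within the scatter, compound 4 is expected to sit close to compound 3, with an estimated step of a 1.2-fold higher number from compound 3 to compound 4 (0.08 log units; within the scatter). The estimate for compound 4 is 125 nM, between 60 nM and 260 nM.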

Compound 4, half-maximal inhibitory concentration: 668 nM
The estimate for compound 4 lay 5.3-fold (0.73 log units) below the measured number; measured number outside the range, above it.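

In this assay, putting amino in place of methylsulfanyl gave a 6.4-fold higher number from compound 3 to compound 4 (0.80 log units; beyond the scatter). The change therefore did not carry over with the same size from one core to the other: the same change on two cores in this assay, a 1.2-fold higher number (0.07 log units; within the scatter) from compound 1 to compound 2 and a 6.4-fold higher number (0.80 log units; beyond the scatter) from compound 3 to compound 4, 5.4-fold (0.73 log units) apart, beyond the scatter of two such steps This shows that the size of the step depended on the core in these two matched pairs, but it does not show which part of the core is responsible, or how the change would behave on a third core.

The compounds shown leave open how other groups at this place, such as a hydroxyl, a methylamino group or a longer thioether chain, would behave on either core. They also leave open whether any of these would show the same dependence on the core.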